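Swapping methoxy for fluoro on compound 3

The source may report more compounds than this note shows. Statements on the series, on what has been measured and on what is new or still open speak of the compounds shown alone.

Three compounds have numbers in a functional assay on U-937 cells (Homo sapiens) for antiproliferative activity, read by MTT assay, with a stated time of 72 h; a lower number here means a stronger inhibitor, a higher number a weaker inhibitor. Compound 1 `O=C(CCCCCCc1nc(-c2ccc(F)cc2)no1)NO` gives 1930 nM, compound 2 `Cc1ccc(-c2noc(CCCCCCC(=O)C(F)(F)F)n2)cc1` gives 3730 nM, and compound 3 `COc1ccc(-c2noc(CCCCCCC(=O)C(F)(F)F)n2)cc1` gives 1170 nM. Compound 3 therefore stands level with compound 1, their gap lying within the usual scatter, while compound 2 is clearly weaker than compound 3.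

Compound 4 `O=C(CCCCCCc1nc(-c2ccc(F)cc2)no1)C(F)(F)F` has not yet been measured. It differs from compound 3 by a single change, fluoro in place of methoxy on an aromatic carbon, turning 4-methoxyphenyl into 4-fluorophenyl. Among the measured compounds shown here, the one measured step on that aromatic carbon is a 3.2-fold lower number from compound 2 to compound 3 (0.50 log units; beyond the scatter), and it swapped methoxy for methyl rather than for fluoro. It shows that this spot can move the number, so a step of similar modest size at most is expected, towards a higher number. Compound 1 also holds the 4-fluorophenyl group but differs elsewhere, so it offers only loose guidance. The expected change is a 1.9-fold higher number from compound 3 to compound 4 (0.27 log units; within the scatter). Compound 4 is estimated at 2200 nM, with an expected range from 1000 nM to 4800 nM.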

Compound 4, half-maximal inhibitory concentration: 2350 nM
Beside the measured number, compound 4's estimate is 1.1-fold (0.03 log units) below it, and the stated range covers the measured number.
By their numbers in this assay, from the lowest: compounds 3, 1, 4 and 2 (each within the scatter of the next, the first and the last beyond it).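

In this assay, fluoro in place of methoxy on this aromatic carbon gives a 2.0-fold higher number from compound 3 to compound 4 (0.30 log units; within the scatter), and fluoro in place of methyl gives a 1.6-fold lower number from compound 2 to compound 4 (0.20 log units; within the scatter). The earlier step between methyl and methoxy, a 3.2-fold lower number from compound 2 to compound 3 (0.50 log units; beyond the scatter), showed that this position can move the number, whereas fluoro cannot be told apart from either group. With the 4-fluorophenyl group held fixed, trifluoromethyl in place of hydroxyamino on a carbonyl carbon gives a 1.2-fold higher number from compound 1 to compound 4 (0.09 log units; within the scatter), so this change elsewhere in the molecule also stays within the scatter.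

No supporting data here offer a reason for these numbers. From the compounds shown here alone, it remains open how an amine, a carboxylic acid or a chlorine atom on this aromatic carbon would behave, and whether a longer chain would alter the number.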